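Swapping the Octylamino Chain for a Piperidine Ring

A few compounds are considered here, and "the series" means these few. Any claim that something is new, unique, unknown or untested is made for them only; others in the source may bear on it.

Measured in a functional assay on HGC-27 cells (Homo sapiens) for cytotoxicity, read by MTT assay, with a stated time of 72 h; a higher number here means a weaker inhibitor, a lower number a stronger inhibitor:
Compound 1, `CCCCCCNc1nc(SCc2ccc(C(F)(F)F)cc2)nc2ccccc12`, gives 23900 nM.
Compound 2, `CCCCCCCCNc1nc(SCc2ccc(C(F)(F)F)cc2)nc2ccccc12`, gives 13400 nM.
Compound 3, `CCCCCCCCCCCCCCNc1nc(SCc2ccc(C(F)(F)F)cc2)nc2ccccc12`, gives > 50000 nM, which is a limit of the assay and not a number.

Compound 2 stands lowest of the two numbers available; compound 1 is nearest, with the step of a 1.8-fold lower number from compound 1 to compound 2 (0.25 log units; within the scatter) lying within the scatter. Compound 3 sits at the limit of > 50000 nM in this assay, at which 1 of the 3 values shown sits. Compound 4, `FC(F)(F)c1ccc(CSc2nc(N3CCCCC3)c3ccccc3n2)cc1`, differs from compound 2 by piperidin-1-yl in place of octylamino on an aromatic carbon. The measured steps all alter chain length only: a 1.8-fold lower number from compound 1 to compound 2 (0.25 log units; within the scatter), an at least 2.0-fold higher number from compound 1 to compound 3 (0.32 log units; beyond the scatter) and an at least 3.7-fold higher number from compound 2 to compound 3 (0.57 log units; beyond the scatter). None exchanges an open chain for a ring, so they bear only loosely on this step, and no step beyond the scatter is expected in this assay. Compound 4 is therefore estimated at 15000 nM, between 5000 nM and 50000 nM, an expected step of a 1.1-fold higher number from compound 2 to compound 4 (0.05 log units; within the scatter).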

Compound 4, half-maximal inhibitory concentration: > 50000 nM
Compound 4 gave a limit, no number; the forecaster's own chance of this, stated with the estimate: 20%; middle value at least 3.3-fold (0.52 log units) away from the limit.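

In this assay, piperidin-1-yl in place of octylamino gives an at least 3.7-fold higher number from compound 2 to compound 4 (0.57 log units; beyond the scatter), and piperidin-1-yl in place of hexylamino gives an at least 2.0-fold higher number from compound 1 to compound 4 (0.32 log units; beyond the scatter). So at this position, a group much shorter than the tetradecyl chain of compound 3 can also end at the limit, which the chain-length steps alone did not show. Compound 4 gives a limit of the assay and not a number: the limit of > 50000 nM in this assay, at which 2 of the 4 values shown sit.

The change removes the open chain and the hydrogen-bond donor together, and the compounds shown do not separate the two. A cyclohexylamino group, a ring that keeps the amine hydrogen, would bear on this, while how far compound 3 and compound 4 lie apart cannot be read.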